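Working notes: tolerability of compounds 1 to 4

The compounds below may be only part of what the source reports. "The series", "measured", "known", "first", "only" and "open" are said of these compounds alone.

Compound 1 `O=C(CCSc1nnc(-c2ccncc2)s1)Nc1ccccc1`, compound 2 `O=C(CCSc1nnc(-c2ccncc2)s1)Nc1ccccc1Cl` and compound 3 `O=C(CSc1nnc(-c2ccncc2)s1)Nc1c(Cl)cccc1Cl` belong to one series; compound 4 `O=C(CSc1nnc(-c2ccncc2)s1)Nc1ccccc1Cl` has not yet been measured. In an ADME assay on HepG2 cells (Homo sapiens) for cytotoxicity, with a stated time of 3 days (a higher number here means that more compound is tolerated, a lower number that less compound is tolerated), compound 1 gives > 50000 nM, which is a limit of the assay rather than a number. In this assay compound 2 gives > 50000 nM, again a limit. For compound 3 the outcome in this assay is "not determined" (no result reported). From compound 2 to compound 1 the change is hydrogen in place of chloro on an aromatic carbon; the step that the two limits leave unreadable from compound 2 to compound 1 has the limit of > 50000 nM in this assay, at which 2 of the 3 values shown sit, at both ends, so its size cannot be read. How the cores of compound 3 and compound 2 differ is not broken down here. From compound 3 to compound 4 the change is hydrogen in place of chloro on an aromatic carbon, the same kind of change as from compound 2 to compound 1, but at a place that is also meta to a chloro group. Compound 4 is expected to give 50000 nM in this assay, within a range from 20000 nM to 120000 nM, most likely reported only as a limit, resting on (the limit of > 50000 nM in this assay, at which 2 of the 3 values shown sit). The measured result for compound 4 follows.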

Compound 4, half-maximal cytotoxic concentration: > 50000 nM
Compound 4 gave a limit, no number (the forecaster's own chance of this, stated with the estimate: 80%); the middle value lies on the limit itself.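

In this assay compound 4 gives > 50000 nM, which is a limit of the assay and not a number. Compound 3 has no value to set against it, so no step can be read between compound 3 and compound 4. The compounds shown leave open whether either chloro group changes tolerance in this assay at all.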